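The source may hold more compounds than are shown below. What is called first, only, known or untested is meant among the compounds shown, and "the series" means these compounds.

Measured compounds:
- Compound 1 `COc1ccc(-c2nc(C)c(C(=O)CSc3nc(-c4ccc(Cl)cc4)c(C#N)c(=O)[nH]3)s2)cc1`: 48%
- Compound 2 `COc1ccc(-c2nc(C)c(C(=O)CSc3nc(-c4cccc(OC)c4)c(C#N)c(=O)[nH]3)s2)cc1`: 43.2%
- Compound 3 `Cc1nc(-c2ccc(Cl)cc2)sc1C(=O)CSc1nc(-c2ccc(Cl)c(Cl)c2)c(C#N)c(=O)[nH]1`: 93.9%

In a functional assay on U-87MG ATCC cells for antiproliferative activity against U-87 MG (Homo sapiens), read by MTT assay, with a stated time of 48 h, tested at 50 uM (a lower number here means a stronger effect, a higher number a weaker effect of the compound at the concentration tested), compound 3 gives 93.9%, the highest of the three numbers, and thus the weakest effect; its gap to compound 1 and to compound 2 lies beyond the scatter in both cases. Compound 4 `COc1ccc(-c2nc(C)c(C(=O)CSc3nc(-c4ccc(Cl)c(Cl)c4)c(C#N)c(=O)[nH]3)s2)cc1`, not yet measured, is made from compound 3 by one change: methoxy in place of chloro on an aromatic carbon.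

For the measured compounds named here, no measured pair differs only in this way. Going by the values given here, the single step that is measured, a number 4.8 percentage points lower from compound 1 to compound 2 (within the scatter), concerns the other aromatic ring of the shared core and lies within the scatter, so it says nothing directly about swapping chloro for methoxy on the ring of compound 4. What can be said is that compound 1 and compound 2, which both carry the methoxy on that ring, sit near the middle of the range, while compound 3, which carries the chloro, sits at the top; but those pairs differ in more than one place.

The expectation for compound 4 is therefore uncertain: the step of a number 33.9 percentage points lower from compound 3 to compound 4 (beyond the scatter) is estimated to run downward, toward a stronger effect, but with wide margins. Compound 4 is expected to give about 60%, between 38% and 92%.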

Compound 4, a percentage reported as activity, at one concentration (the size of the read-out at that concentration, not a potency): 78.4%
Compound 4: the middle estimate sits 18.4 percentage points below what was measured; measured number inside the range.
By their numbers in this assay, from the lowest: compounds 2 and 1 (each within the scatter of the next); then compound 4; then compound 3.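

Read as 4-chlorophenyl to 4-methoxyphenyl, the swap of chloro for methoxy gives, in this assay, a number 15.5 percentage points lower from compound 3 to compound 4 (beyond the scatter), so this position responds to the change, with a modest step toward a stronger effect. The other aromatic ring shows large steps toward a weaker effect: chloro in place of hydrogen gives a number 30.4 percentage points higher from compound 1 to compound 4 (beyond the scatter), and 3,4-dichlorophenyl in place of 3-methoxyphenyl gives a number 35.2 percentage points higher from compound 2 to compound 4 (beyond the scatter), whereas the earlier change on that ring, a number 4.8 percentage points lower from compound 1 to compound 2 (within the scatter), had revealed no such sensitivity. Nothing measured here explains either the modest step or the large ones.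

From the compounds shown here alone, the methoxy-for-chloro swap is seen in this one pair only, so it remains open whether it would give a similar step with 4-chlorophenyl or 3-methoxyphenyl on the other ring. Going by these compounds, how a dimethylamino group or a carboxylic acid in the same place, para to a large group, would read in this assay also remains open.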